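Returning an aryl group to the aromatic nitrogen

The compounds below may be only part of what the source reports. "The series", "measured", "known", "first", "only" and "open" are said of these compounds alone.

Compound 1 `CC(C)(C)c1cc(NC(=O)Nc2cc(F)cc(F)c2)n(-c2ccc(F)cc2)n1`: 1.9 degrees C
Compound 2 `CC(C)(C)c1cc(NC(=O)Nc2cc(F)cc(F)c2)n(C(C)(C)C)n1`: 0 degrees C

Both compounds were measured in an assay on isolated protein for inhibition of Ephrin type-A receptor 2 (Homo sapiens), read by thermal shift assay, tested at 10 uM; on this read-out lower numbers stand for weaker stabilisation of the target and higher numbers for stronger stabilisation of the target against heat. Going by the values given here, compound 1 gives 1.9 degrees C there, and compound 2 gives 0 degrees C, which is the lowest of the two numbers; the only step so far, a number 1.9 degrees C lower from compound 1 to compound 2 (beyond the scatter), separates them. Compound 3 `CC(C)(C)c1cc(NC(=O)Nc2cc(F)cc(F)c2)n(-c2ccc(Br)cc2)n1` has not been measured yet. It differs from compound 2 in one place: 4-bromophenyl in place of tert-butyl on an aromatic nitrogen. Among the compounds with values here, the one measured step that bears on this change runs the other way, since going from compound 1 to compound 2 exchanged a 4-fluorophenyl for the tert-butyl and gave a number 1.9 degrees C lower from compound 1 to compound 2 (beyond the scatter). Compound 3 puts an aryl group, now 4-bromophenyl, back on that aromatic nitrogen, so a gain of about the same size is expected, a number 2.0 degrees C higher from compound 2 to compound 3 (beyond the scatter). Compound 3 is therefore estimated at 2 degrees C, with a range from 0.5 degrees C to 3.5 degrees C.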

Compound 3, shift of the target's melting temperature: 1.3 degrees C
For compound 3 the middle estimate is 0.70 degrees C above the measured one; the range from low to high includes it.
By their numbers in this assay, from the lowest: compound 2; then compounds 3 and 1 (each within the scatter of the next).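

In this assay the step to a second aryl group (a number 1.3 degrees C higher from compound 2 to compound 3 (beyond the scatter)) shows that the tert-butyl result is not specific to the comparison with 4-fluorophenyl: with 4-bromophenyl on the aromatic nitrogen, the stabilisation again stands clear of that of compound 2. The halogen exchange on this aryl group (a number 0.60 degrees C lower from compound 1 to compound 3 (within the scatter)) shows that bromo in place of fluoro on an aromatic carbon does not separate the two aryl compounds on this read-out. Nothing measured here gives a reason for the difference between the aryl and tert-butyl compounds.

The compounds shown leave open whether an unsubstituted phenyl or a benzyl group on that nitrogen would behave like the two halogenated aryl groups. They also do not say how an amine or a carboxylic acid on the aryl ring would fare.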